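Methyl on the anilide ring across two cores

The source may report more compounds than this note shows. Statements on the series, on what has been measured and on what is new or still open speak of the compounds shown alone.

Measured so far in an assay on cells for inhibition of Amine oxidase [flavin-containing] B (Homo sapiens), read by fluorescence and Amplex Red, using microsomes, with a stated time of 15 min; a lower number here means a stronger inhibitor, a higher number a weaker inhibitor:
compound 1, `Cc1ccc2occ(C(=O)Nc3ccccc3)c(=O)c2c1`, gives 21.4 nM;
compound 2, `Cc1cccc(NC(=O)c2coc3ccc(C)cc3c2=O)c1`, gives 17.1 nM;
compound 3, `COc1ccc2oc(=O)c(C(=O)Nc3ccccc3)cc2c1`, gives 5.95 nM.

Compound 3 stands lowest of the three; its gap to compound 2 and its gap to compound 1 are both beyond the scatter. How the core of compound 3 differs from the core of compound 1 is not broken down here.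

Compounds 1 and 2 share one core and differ by methyl in place of hydrogen on an aromatic carbon. The step of a 1.3-fold lower number from compound 1 to compound 2 (0.10 log units; within the scatter) lies within the scatter, so these two values show no change that can be read.

Compound 4, `COc1ccc2oc(=O)c(C(=O)Nc3ccc(C)cc3)cc2c1`, is not yet measured. It differs from compound 3 by methyl in place of hydrogen on an aromatic carbon. For the measured compounds named here, this is the same kind of change as the one from compound 1 to compound 2, but not the same: in compound 2 the methyl sits meta to a large group, in compound 4 it sits para to a large group.

Going by the values given here, the only comparable pair is compound 1 and compound 2, where the step was within the scatter, so the step from compound 3 to compound 4 in this assay is expected to be small as well, about a 1.2-fold lower number from compound 3 to compound 4 (0.08 log units; within the scatter). The methyl takes a different position here. Among the compounds with values here, no measured pair shows this position, so the expectation is widened. For compound 4 the expected value is 5 nM, with a range from 2.5 nM to 10 nM.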

Compound 4, half-maximal inhibitory concentration: 19.4 nM
For compound 4 the middle estimate is 3.9-fold (0.59 log units) below the measured one; measured number outside the range, above it.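

In this assay, methyl in place of hydrogen on an aromatic carbon does not carry the same size of step from one core to the other: the same change on two cores in this assay, a 1.3-fold lower number (0.10 log units; within the scatter) from compound 1 to compound 2 and a 3.3-fold higher number (0.51 log units; beyond the scatter) from compound 3 to compound 4, 4.1-fold (0.61 log units) apart, beyond the scatter of two such steps

On the core of compound 3, the change from phenyl to 4-methylphenyl gives a 3.3-fold higher number from compound 3 to compound 4 (0.51 log units; beyond the scatter), so the near-flat result on the core of compound 1 is a poor guide to this step on the core of compound 3. The two steps differ in the place of the methyl as well as in the core, and with only these two pairs the shown data cannot say how much of the gap belongs to the core and how much to the methyl position.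

Open, as far as these compounds go, are the same 4-methylphenyl change on the core of compound 1 and, on the core of compound 3, a methyl in the position it holds in compound 2, either of which would separate core from position. Also open, from the compounds shown here alone, is how the anilide ring of compound 3 responds to groups other than methyl, such as an amine or a carboxylic acid, in the place para to a large group.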